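The compounds below may be only part of what the source reports. "The series", "measured", "known", "first", "only" and "open" are said of these compounds alone.

Measured so far in a functional assay on HT-29 cells (Homo sapiens); on this read-out lower numbers stand for stronger inhibition of growth and higher numbers for weaker inhibition of growth:
- compound 1 `O=S(=O)(/C=C/c1ccc(C(F)(F)F)cc1F)Cc1ccc(Nc2ncnc3ccccc23)cc1`: 100000 nM
- compound 2 `O=S(=O)(/C=C/c1ccc(C(F)(F)F)cc1F)Cc1ccc(Nc2ncnc3ccc(Br)cc23)cc1`: 100000 nM
- compound 3 `O=S(=O)(/C=C/c1ccc(Cl)cc1Cl)Cc1ccc(Nc2ncnc3cc(Cl)ccc23)cc1`: 59000 nM

In this assay compound 3 gives 59000 nM, which lies within the scatter of the values of compound 1 and compound 2. All three therefore sit together.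

The next structure is compound 4 `O=S(=O)(/C=C/c1ccc(C(F)(F)F)cc1F)Cc1ccc(Nc2ncnc3cc(Cl)ccc23)cc1`, not yet measured. The change from compound 3 is 2-fluoro-4-(trifluoromethyl)phenyl in place of 2,4-dichlorophenyl on a double-bonded chain carbon bound to a double-bonded chain carbon. It replaces 2,4-dichlorophenyl with 2-fluoro-4-(trifluoromethyl)phenyl on a double-bonded chain carbon bound to a double-bonded chain carbon.

Among the measured compounds shown here, no measured step makes this exchange. For the measured compounds named here, the only one available shows no change at the digits printed from compound 1 to compound 2 (within the scatter), for bromo in place of hydrogen on an aromatic carbon, so it bears only indirectly. The entering group is also carried by compound 1 at 100000 nM and by compound 2 at 100000 nM, and neither value stands apart from that of compound 3.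

No step beyond the scatter is therefore expected, and the estimated move is a 1.4-fold higher number from compound 3 to compound 4 (0.16 log units; within the scatter). The expected value for compound 4 is 85000 nM, within an estimated range of 50000 nM to 110000 nM.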

Compound 4, concentration for 50% growth inhibition: > 100000 nM
Compound 4 ended at the assay's limit; the forecaster's own chance of this, stated with the estimate: 25%; middle value at least 1.1-fold (0.07 log units) from the limit.
By their numbers in this assay, from the lowest: compounds 3, 1 and 2 (each within the scatter of the next).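

Compound 4 stands at > 100000 nM in this assay, which is a limit of the assay and not a number. On these data alone, at the place on a double-bonded chain carbon bound to a double-bonded chain carbon, 2-fluoro-4-(trifluoromethyl)phenyl in place of 2,4-dichlorophenyl shows an at least 1.6-fold higher number from compound 3 to compound 4 (0.22 log units; that floor lies within the scatter), so this exchange brings no gain in growth inhibition, while its true size remains unknown. The data also give a number no lower from compound 2 to compound 4 (the limit leaves the size open) and a number no lower from compound 1 to compound 4 (the limit leaves the size open), and these two steps cannot be read, because the limit leaves their size open: the limit of > 100000 nM in this assay, at which 1 of the 4 values shown sits.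

At this place the compounds shown carry only 2,4-dichlorophenyl and 2-fluoro-4-(trifluoromethyl)phenyl. As far as these compounds go, how an amine or a carboxylic acid in place of either group would read in this assay stays open.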